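From 4-cyanophenyl to 2-methylpyridin-3-yl at the limit

The source may report more compounds than this note shows. Statements on the series, on what has been measured and on what is new or still open speak of the compounds shown alone.

In a physicochemical assay for solubility, in phosphate buffer, at pH 7.4 (a higher number here means a more soluble compound, a lower number a less soluble compound), compound 1 `OCC1CCN(c2nccnc2OC2CN(c3ccc4ccccc4n3)C2)C1` gives 167000 nM as a measured number. Compound 2 `c1ccc(-c2nccnc2OC2CN(c3ccc4ccccc4n3)C2)cc1` shows < 1000 nM as a limit only. Compound 3 `N#Cc1ccc(-c2nccnc2OC2CN(c3ccc4ccccc4n3)C2)cc1` also shows < 1000 nM as a limit only, and so stands at the limit of < 1000 nM in this assay, at which 2 of the 3 values shown sit, with no number of its own. Compound 4 `Cc1ncccc1-c1nccnc1OC1CN(c2ccc3ccccc3n2)C1` carries 2-methylpyridin-3-yl in place of 4-cyanophenyl on an aromatic carbon and has not been measured. Within the data shown here, three steps bear on this: an at least 160-fold lower number from compound 1 to compound 2 (2.22 log units; beyond the scatter) and an at least 160-fold lower number from compound 1 to compound 3 (2.22 log units; beyond the scatter) were both large, while a step that the two limits leave unreadable from compound 2 to compound 3 gives no size. Compound 4 keeps a six-membered aromatic ring at that place, as compound 3 does, so an at least 160-fold lower number from compound 1 to compound 3 (2.22 log units; beyond the scatter) is not expected to be undone. Only a small upward move is expected, with an at least 1.5-fold higher number from compound 3 to compound 4 (0.17 log units; that floor lies within the scatter) as the estimated step in this assay here. For compound 4 the expected value is 1500 nM in a range from 300 nM to 10000 nM as estimated.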

Compound 4, solubility: 253000 nM
Estimate against measurement, compound 4: 170-fold (2.23 log units) below, and the stated range ends below it.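

In this assay, a six-membered aromatic ring on this carbon need not sit low, with an at least 250-fold higher number from compound 3 to compound 4 (2.40 log units; beyond the scatter) and an at least 250-fold higher number from compound 2 to compound 4 (2.40 log units; beyond the scatter). Both of these steps start from a limit, not a number: the limit of < 1000 nM in this assay, at which 2 of the 4 values shown sit. There is also a 1.5-fold higher number from compound 1 to compound 4 (0.18 log units; within the scatter), so 2-methylpyridin-3-yl and 3-(hydroxymethyl)pyrrolidin-1-yl cannot be told apart at this place.

On these data alone, the step between compound 2 and compound 3 cannot be read, so what the nitrile contributes stays open. The compounds shown also do not separate the ring nitrogen from the methyl, which a pyridin-3-yl or a 2-methylphenyl group at this place could do.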